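This account rests on a few compounds, and the source may have more. Where it says the series, first, only, none or still open, it means among the compounds named here.

Working notes on the hydrazone series.

Of the compounds shown here, three have been measured in a functional assay on Caco-2 cells (Homo sapiens) for inhibition, read by MTT assay, with a stated time of 48 h; on this read-out higher numbers stand for weaker inhibition and lower numbers for stronger inhibition. Compound 1 `Fc1ccc(/C=N/Nc2nc(-c3ccc(C(F)(F)F)cc3)cs2)cc1F` gives 14600 nM in this assay. Compound 3 `Fc1ccc(/C=N/Nc2nc(-c3ccc(F)c(F)c3)cs2)cc1F` gives 14200 nM in this assay, a number within the scatter of compound 1. Compound 2 `COc1cc(/C=N/Nc2nc(-c3ccc(Br)cc3)cs2)cc(Br)c1OC` gives 36200 nM in this assay; this is the highest of the three numbers, and its gaps to compound 1 and to compound 3 both lie beyond the scatter, so compound 2 shows the weakest inhibition of the set.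

Compound 4 `COc1cc(/C=N/Nc2nc(-c3ccc(F)c(F)c3)cs2)cc(Br)c1OC` has not been measured. Compound 4 differs from compound 2 by 3,4-difluorophenyl in place of 4-bromophenyl on an aromatic carbon. Within the data shown here, no measured pair tells the size of this exact change. What the numbers show is that compound 1 and compound 3, which carry different aryl groups on the shared core and the same aldehyde-derived part, sit within the scatter of each other; on that ground, no large step is expected.

The step from compound 2 to compound 4 is expected to be a 1.2-fold lower number from compound 2 to compound 4 (0.08 log units; within the scatter), small and within the usual scatter, with no firm direction. Compound 4 is estimated at 30000 nM in this assay, with a range from 12000 nM to 75000 nM.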

Compound 4, half-maximal inhibitory concentration: 21200 nM
The estimate for compound 4 lay 1.4-fold (0.15 log units) above the measured number; the range from low to high includes it.
By their numbers in this assay, from the lowest: compounds 3, 1, 4 and 2 (each within the scatter of the next, the first and the last beyond it).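

In this assay, 3,4-difluorophenyl in place of 4-bromophenyl, on the aromatic carbon next to the ring nitrogen of the five-membered ring, gives a 1.7-fold lower number from compound 2 to compound 4 (0.23 log units; within the scatter). Among these compounds, this is the only pair in the set that isolates a change at this position while the rest of the structure stays the same, and it shows that these two halogen-bearing phenyl groups cannot be told apart in this read-out when the aldehyde-derived part of compound 2 is kept. No independent measurement is at hand that would account for this result or link it to any property of either group.

The compounds shown all carry a halogen-bearing phenyl group at this position, so it remains open whether a phenyl ring bearing an amine or a carboxylic acid, or a small alkyl group such as methyl in place of the phenyl ring, would move the number beyond the scatter. From the compounds shown here alone, it is also open whether the same exchange would give a similar step with a different aldehyde-derived part.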